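Chloro in Place of Nitro: Expected Cytotoxicity of Compound 4

The source may hold more compounds than are shown below. What is called first, only, known or untested is meant among the compounds shown, and "the series" means these compounds.

Measured in an ADME assay on HEL cells (Homo sapiens) for cytotoxicity; on this read-out lower numbers stand for higher toxicity in this test and higher numbers for lower toxicity in this test:
compound 1, `O=C(COc1cccc2ccccc12)N/N=C/c1c(O)ccc2ccccc12`, gives 4 ug/mL.
compound 2, `O=C(COc1cccc2ccccc12)N/N=C/c1cccc([N+](=O)[O-])c1`, gives only a limit, >= 20 ug/mL.
compound 3, `O=C(COc1cccc2ccccc12)N/N=C/c1c[nH]c2ccccc12`, gives 100 ug/mL.

Compound 2 stands at a limit of this assay rather than at a number: the limit of >= 20 ug/mL in this assay, at which 1 of the 3 values shown sits. The two numbers shown lie far apart, compound 1 at 4 ug/mL and compound 3 at 100 ug/mL, and compound 2 cannot be placed precisely against either of them. Within the data shown here, no step between two measured compounds that differ in one place is available, so the spread across the shared core of compound 1 is the only guide to how widely values of this kind can run here.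

Compound 4, `O=C(COc1cccc2ccccc12)N/N=C/c1cccc(Cl)c1`, has not yet been measured in this assay. It differs from compound 2 in one place: chloro in place of nitro on an aromatic carbon. Among the measured compounds shown here, nothing among the measured compounds shows what this change does in this assay. The step is therefore expected to be small, most likely within the scatter, with the limit of compound 2 leaving its direction open; the expected step is a number no higher from compound 2 to compound 4 (the limit leaves the size open). On that basis compound 4 is estimated at 20 ug/mL in this assay, with a range from 5 ug/mL to 100 ug/mL.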

Compound 4, minimum cytotoxic concentration: 100 ug/mL
For compound 4 the middle estimate is 5.0-fold (0.70 log units) below the measured one; the range from low to high includes it.
By their numbers in this assay, from the lowest: compound 1; then compounds 3 and 4 (each within the scatter of the next).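

No step can be read from compound 2 to compound 4 in this assay, because compound 2 stands at a limit of the assay and not at a number: the limit of >= 20 ug/mL in this assay, at which 1 of the 4 values shown sits.

The compounds shown leave open how large the effect of chloro in place of nitro on an aromatic carbon is, and in which direction it runs.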